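This account rests on a few compounds, and the source may have more. Where it says the series, first, only, none or still open, it means among the compounds named here.

In a functional assay on K562 cells (Homo sapiens) for cytotoxicity, read by XTT assay, with a stated time of 24 h (a higher number here means a weaker inhibitor, a lower number a stronger inhibitor), compound 1 (`Cc1ccc(NC(=O)c2ccc(Br)cc2OCCCCn2ccnc2)cc1Nc1nccc(-c2cccnc2)n1`) gives 66100 nM. That number lies within the scatter of compound 3 (`Cc1ccc(NC(=O)c2cccc(OCCCCn3ccnc3)c2)cc1Nc1nccc(-c2cccnc2)n1`) at 74600 nM, while compound 2 (`COc1ccc(C(=O)Nc2ccc(C)c(Nc3nccc(-c4cccnc4)n3)c2)cc1OCCCCn1ccnc1`) reads clearly lower at 10100 nM. Compound 1 therefore sits with compound 3 at the weak end of this small set.

Compound 4 (`Cc1ccc(NC(=O)c2ccccc2OCCCCn2ccnc2)cc1Nc1nccc(-c2cccnc2)n1`) differs from compound 1 in a single place: hydrogen in place of bromo on an aromatic carbon. This puts hydrogen in place of bromo on an aromatic carbon, para to a large group and meta to a 4-(1H-imidazol-1-yl)butoxy group.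

Among the measured compounds shown here, only one measured step bears on this change: a 7.4-fold higher number from compound 2 to compound 3 (0.87 log units; beyond the scatter), where hydrogen replaces methoxy on an aromatic carbon. That step is modest but beyond the scatter, and it would suggest a rise. It is an imperfect guide, however, since the departing group is different and compound 2 and compound 3 carry the butoxy group elsewhere on the ring. Compound 3 also shows that a compound without such a group can read 74600 nM, level with compound 1. In this assay, no step beyond the scatter is therefore expected. The expected change is a 1.1-fold higher number from compound 1 to compound 4 (0.04 log units; within the scatter). For compound 4 the estimated value is 72000 nM, with an expected range from 30000 nM to 150000 nM.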

Compound 4, half-maximal inhibitory concentration: 47500 nM
Compound 4: the middle estimate sits 1.5-fold (0.18 log units) above what was measured; low and high end bracket the measured number.
By their numbers in this assay, from the lowest: compound 2; then compounds 4, 1 and 3 (each within the scatter of the next).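

In this assay, the change from bromo to hydrogen on the aromatic carbon para to a large group and meta to a 4-(1H-imidazol-1-yl)butoxy group gives a 1.4-fold lower number from compound 1 to compound 4 (0.14 log units; within the scatter) and so stays within the scatter. Among the compounds shown here, this is the first direct reading at this position, and it shows that, between these two compounds, bromo and hydrogen cannot be told apart in this read-out, whereas the only earlier step, a 7.4-fold higher number from compound 2 to compound 3 (0.87 log units; beyond the scatter), involved a different departing group at a different place and lay beyond the scatter. No measurement given here explains why this exchange leaves the number within the scatter.

With only bromo and hydrogen shown at this carbon, a single pair cannot show whether the position is insensitive to substitution in general or whether these two substituents merely happen to read alike. A methoxy group, an amine or a carboxylic acid at this same position would be needed to settle that, and the compounds shown also leave open whether the methoxy step seen elsewhere on the ring would carry over to this carbon.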